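The source may report more compounds than this note shows. Statements on the series, on what has been measured and on what is new or still open speak of the compounds shown alone.

Of the compounds shown here, three built on one shared core have been measured for how much of an oral dose reaches the bloodstream. Compound 3 `CCn1c(-c2cnc(C)nc2)nc2c(N[C@H]3CCN(C(=O)C4CC4)C3)ncnc21` carries a cyclopropyl group on a carbonyl carbon whose other neighbour is an amide-type nitrogen in a ring. In an ADME assay on the whole organism (Canis lupus familiaris, strain Beagle) for pharmacokinetics (on this read-out higher numbers stand for higher oral bioavailability and lower numbers for lower oral bioavailability), compound 3 gives 95%. Compound 1 `CCn1c(-c2cnc(C)nc2)nc2c(N[C@H]3CCN(C(=O)[C@H]4C[C@@H](OC)C4)C3)ncnc21` differs from it in one place, (3-methoxycyclobutyl in place of cyclopropyl on a carbonyl carbon), and in this assay compound 1 gives 85%; the step is a number 10 percentage points lower from compound 3 to compound 1 (within the scatter). Compound 2 `CCn1c(-c2cnc(C)nc2)nc2c(O[C@H]3CCN(C(=O)C4CC4)C3)ncnc21` has a core that differs from that of compound 3 in a way that is not broken down here, and in this assay compound 2 gives 100%. The values of compound 2 and compound 3 lie within the usual scatter of each other, while the values of compound 2 and compound 1 lie further apart than that scatter.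

Compound 4 `CCn1c(-c2cnc(C)nc2)nc2c(O[C@H]3CCN(C(=O)[C@H]4C[C@@H](OC)C4)C3)ncnc21` has not yet been measured. It differs from compound 2 by 3-methoxycyclobutyl in place of cyclopropyl on a carbonyl carbon, which is the same change, at the same kind of place, as that from compound 3 to compound 1. Since that earlier change gave a number 10 percentage points lower from compound 3 to compound 1 (within the scatter), a step of similar size is expected from compound 2 to compound 4, namely a number 10 percentage points lower from compound 2 to compound 4 (within the scatter), bearing in mind that the read-out cannot rise above complete absorption. On that basis compound 4 is expected to give about 90% in this assay, most likely between 75% and 100%.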

Compound 4, oral bioavailability: 80%
The estimate for compound 4 lay 10 percentage points above the measured number, within the range that was stated.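

In this assay, putting 3-methoxycyclobutyl in place of cyclopropyl on the carbonyl carbon gives a number 20 percentage points lower from compound 2 to compound 4 (beyond the scatter). Set beside the earlier case on the other core, the two steps do not differ by more than repeated measurements would be expected to: the same change on two cores in this assay, a number 10 percentage points lower (within the scatter) from compound 3 to compound 1 and a number 20 percentage points lower (beyond the scatter) from compound 2 to compound 4, 10 percentage points apart, within the scatter of two such steps So, for these two pairs, the effect of the change carries over from one core to the other, but this rests on only one pair per core, says nothing about other cores, and does not explain why the step on the core of compound 2 lies beyond the scatter while the step on the core of compound 3 lies within it.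

The change swaps the ring and adds the methoxy group in one move, so the compounds shown cannot separate what each part contributes. As far as these compounds go, how a plain cyclobutyl without the methoxy group, or an open chain such as isopropyl, would behave on this carbonyl carbon remains open, as does whether any such group would carry over between the two cores in the same way.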